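From Compound 2 to Compound 3: A Trifluorophenyl Exchange

The source may report more compounds than this note shows. Statements on the series, on what has been measured and on what is new or still open speak of the compounds shown alone.

compound 1 `CC(C)c1cccc(C(C)C)c1NC(=O)CC(=O)Oc1c(-c2ccccc2)cccc1-c1ccccc1`: 67 nM
compound 2 `CC(C)c1cccc(C(C)C)c1OC(=O)CC(=O)Nc1ccccc1`: > 5000 nM

In an assay on microsomes from intestine for inhibition of acyl-CoA:cholesterol acyltransferase (Oryctolagus cuniculus) (on this read-out higher numbers stand for weaker inhibition and lower numbers for stronger inhibition), compound 1 gives 67 nM. Compound 2 is a different case: in this assay compound 2 gives > 5000 nM, which is a limit of the assay and not a measured number. Going by the values given here, compound 2 therefore stands at the limit of > 5000 nM in this assay, at which 1 of the 2 values shown sits, while compound 1 is the one value that is a number. Among the compounds with values here, no computed step between compound 1 and compound 2 exists, so nothing beyond these two readings is said of that pair.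

Compound 3 `CC(C)c1cccc(C(C)C)c1OC(=O)CC(=O)Nc1c(F)cc(F)cc1F` is not yet measured. It differs from compound 2 by 2,4,6-trifluorophenyl in place of phenyl on an amide-type nitrogen. Since compound 2 itself reaches only the limit of this assay, any step from it can be read in one direction only, and the step from compound 2 to compound 3 is expected to be a step that the limit leaves unreadable from compound 2 to compound 3, that is, no clear movement beyond the scatter. Compound 3 is accordingly estimated at 6000 nM, with a range from 1500 nM to 20000 nM, and a real chance that it too returns only a limit.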

Compound 3, half-maximal inhibitory concentration: > 5000 nM
Compound 3: a limit, no number (the forecaster's own chance of this, stated with the estimate: 60%); the middle value is on the limit's open side.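

Compound 2 and compound 3 both return only a limit in this assay, not a number, so no step can be read between them: the limit of > 5000 nM in this assay, at which 2 of the 3 values shown sit.

Going by these compounds, whether 2,4,6-trifluorophenyl in place of phenyl on an amide-type nitrogen changes the inhibition at all, and in which direction, remains open.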